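Working notes: carbonyl-aryl change from compound 2 to compound 3

The source may hold more compounds than are shown below. What is called first, only, known or untested is meant among the compounds shown, and "the series" means these compounds.

compound 1 `COc1cc(-c2cc(/C=C/C(=O)c3ccc(Cl)c(Cl)c3)[nH]n2)cc(OC)c1OC`: 50%
compound 2 `COc1ccc(C(=O)/C=C/c2cc(-c3cc(OC)c(OC)c(OC)c3)n[nH]2)cc1`: -59%

In a functional assay on 786-0 cells (Homo sapiens) for cytotoxicity, read by sulforhodamine B assay, with a stated time of 48 h, tested at 10 uM (a higher number here means a weaker effect of the compound at the concentration tested, a lower number a stronger effect), compound 2 gives the lowest of the two numbers, and the gap to its nearest neighbour is beyond the scatter. Compound 3 `COc1cc(-c2cc(/C=C/C(=O)c3ccc(F)c(F)c3)[nH]n2)cc(OC)c1OC` differs from compound 2 by 3,4-difluorophenyl in place of 4-methoxyphenyl on a carbonyl carbon. Among the compounds with values here, the one measured step that bears on this is a number 109 percentage points lower from compound 1 to compound 2 (beyond the scatter), where 4-methoxyphenyl replaced 3,4-dichlorophenyl on the same carbonyl carbon. Since compound 3 again carries a dihalophenyl there, a step in the reverse direction, part way back, is expected. Compound 3 is estimated at 15%, range -30% to 55%, an expected step of a number 74 percentage points higher from compound 2 to compound 3 (beyond the scatter).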

Compound 3, a percentage reported as activity, at one concentration (the size of the read-out at that concentration, not a potency): 11%
For compound 3 the middle estimate is 4 percentage points above the measured one, and the stated range covers the measured number.
By their numbers in this assay, from the lowest: compound 2; then compound 3; then compound 1.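

In this assay, the carbonyl-carbon position distinguishes between two dihalophenyl groups: 3,4-difluorophenyl in place of 3,4-dichlorophenyl gives a number 39 percentage points lower from compound 1 to compound 3 (beyond the scatter), so the identity of the halogen matters here, not just the presence of a dihalophenyl. Replacing 4-methoxyphenyl with the same group still gives a number 70 percentage points higher from compound 2 to compound 3 (beyond the scatter), leaving compound 2 with the lowest number of the three. Nothing at hand accounts for either step. Open, on these data alone, is how a phenyl carrying an amine or a carboxylic acid would compare with 4-methoxyphenyl at this carbonyl carbon.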